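A few compounds are considered here, and "the series" means these few. Any claim that something is new, unique, unknown or untested is made for them only; others in the source may bear on it.

Compound 1 `O=c1oc2c(O)cccc2cc1-c1ccccc1` and compound 2 `O=c1oc2c(O)c(O)ccc2cc1-c1ccccc1` share one core and differ by a single group. In a functional assay on CHO cells for antagonist activity at adenosine receptor A2b (Homo sapiens), read by cAMP accumulation (a higher number here means a weaker inhibitor, a lower number a stronger inhibitor), compound 1 gives > 30000 nM, which is a limit of the assay and not a number. In this assay compound 2 likewise gives > 30000 nM, again a limit rather than a number. The step that the two limits leave unreadable from compound 1 to compound 2 therefore cannot be read for size, since both values sit at the limit of > 30000 nM in this assay, at which 2 of the 2 values shown sit. Compound 2 thus stands only at a limit, with nothing beneath it resolved. Compound 3 `O=c1oc2c(O)c(O)ccc2cc1-c1ccc(O)cc1` differs from compound 2 by hydroxy in place of hydrogen on an aromatic carbon. Among the measured compounds shown here, no measured step has a readable size, so the sole guide is that the same kind of change from compound 1 to compound 2 left the value at the limit. Compound 3 is therefore expected to remain near the limit, with the step that the limit leaves unreadable from compound 2 to compound 3 expected to be none beyond the scatter. The estimate for compound 3 in this assay is 40000 nM, within a range from 8000 nM to 200000 nM.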

Compound 3, half-maximal inhibitory concentration: > 30000 nM
Compound 3 gave a limit, no number; the forecaster's own chance of this, stated with the estimate: 80%; the middle value does not contradict the limit.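

No new step can be read, since compound 3, like compound 2, stands at a limit of the assay and not at a number: the limit of > 30000 nM in this assay, at which 3 of the 3 values shown sit. In this assay the compounds shown leave open what inhibitory strength, if any, lies beyond that limit for this series.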